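A few compounds are considered here, and "the series" means these few. Any claim that something is new, unique, unknown or untested is made for them only; others in the source may bear on it.

Compound 1, `Cn1nc2c(=O)n(CC3(O)CCN(Cc4ccc(-c5ccco5)cc4Cl)CC3)cnc2c1-c1ccc(F)cc1`: 64.5 nM
Compound 2, `Cc1ccc(-c2ccc(CN3CCC(O)(Cn4cnc5c(-c6ccc(CN)cc6)n(C)nc5c4=O)CC3)c(Cl)c2)s1`: 101 nM
Compound 3, `Cn1nc2c(=O)n(CC3(O)CCN(Cc4ccc(-c5ncco5)cc4Cl)CC3)cnc2c1-c1ccc(CN)cc1`: 1120 nM

These three compounds were tested in an assay on isolated protein for inhibition of ubiquitin carboxyl-terminal hydrolase 7 (Homo sapiens), with stated times of 30 min and 2 h; a lower number here means a stronger inhibitor, a higher number a weaker inhibitor. Compound 1 gives the lowest of the three numbers; compound 2 lies close to it, inside the scatter of repeated measurements, whereas compound 3 sits well beyond that scatter. Compound 1 and compound 3 differ in more than one place, so their gap cannot be tied to any single group. Among the compounds with values here, the only single-change step that has been measured runs an 11-fold higher number from compound 2 to compound 3 (1.04 log units; beyond the scatter), and it concerns a different part of the shared core from the change considered here.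

Compound 4, `Cn1nc2c(=O)n(CC3(O)CCN(Cc4ccc(-c5ccco5)cc4Cl)CC3)cnc2c1-c1ccc(Cl)cc1`, has not yet been measured. It differs from compound 1 in one way: chloro in place of fluoro on an aromatic carbon. Within the data shown here, no measured pair shows what exchanging one halogen for another at this spot does, so the step from compound 2 to compound 3 offers no direct guide. With nothing pointing in either direction, the expectation is a step that stays within the usual scatter, a 1.1-fold lower number from compound 1 to compound 4 (0.03 log units; within the scatter). Compound 4 is therefore estimated at 60 nM in this assay, with a likely range from 25 nM to 150 nM.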

Compound 4, half-maximal inhibitory concentration: 143 nM
For compound 4 the middle estimate is 2.4-fold (0.38 log units) below the measured one; measured number inside the range.
By their numbers in this assay, from the lowest: compounds 1, 2 and 4 (each within the scatter of the next, the first and the last beyond it); then compound 3.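

Read in this assay, the exchange of fluoro for chloro gives a 2.2-fold higher number from compound 1 to compound 4 (0.35 log units; beyond the scatter), a modest step, but one that lies beyond the usual scatter. Within the data shown here, this is the first direct sign that this position responds to a change of a single atom: with the rest of compound 1 left as it is, the 4-fluorophenyl group gives the lower number and the 4-chlorophenyl group the higher one. Nothing measured here explains why the two halogens differ in this way.

On these data alone, two halogens give only two points at this place, so it remains open whether bromo would raise the number further, and what a plain hydrogen, a methyl group or a methoxy group would give on the same aromatic carbon. Among these compounds, it also remains open whether the exchange would give a step of similar size elsewhere, since the only pair that shows it is built on the core of compound 1 and carries the same groups at every other place.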